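Stereochemistry at the core and cytotoxic potency

The source may hold more compounds than are shown below. What is called first, only, known or untested is meant among the compounds shown, and "the series" means these compounds.

Measured compounds:
compound 1, `C#C[C@@]1(O)[C@H](O)[C@@H](CO)O[C@H]1n1ccc(N)nc1=O`: > 350000 nM
compound 2, `C#CC[C@]1(O)[C@@H](CO)OC(n2ccc(N)nc2=O)[C@@H]1O`: > 350000 nM
compound 3, `C#C[C@]1(O)[C@H](O)[C@@H](CO)O[C@H]1n1ccc(N)nc1=O`: > 350000 nM

In a functional assay on KB cells (Homo sapiens), read by MTT assay (on this read-out lower numbers stand for stronger inhibition and higher numbers for weaker inhibition), compound 1 gives > 350000 nM, which is a limit of the assay and not a number. Compound 3 gives > 350000 nM in this assay, again a limit. Compound 2 stands at > 350000 nM in this assay, likewise a limit, so only a limit is known for it, as for the other two values shown.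

Among the measured compounds shown here, the single step between compounds differing in one place is a step that the two limits leave unreadable from compound 1 to compound 3; the two compounds differ only in configuration as drawn (the fact that compounds 1 and 3 differ only in the configuration as drawn), and its size cannot be read.

Compound 4, `C#CC[C@@]1(O)[C@@H](CO)O[C@@H](n2ccc(N)nc2=O)[C@@H]1O`, has not been measured in this assay. It differs from compound 2 as follows: the two compounds have the same atoms and bonds; at least one stereo element is drawn with a configuration in one of them and without one in the other: 2 of 4 stereo elements differ; a stereocentre at a saturated ring carbon is drawn R in compound 2 and S in compound 4; a stereocentre at a saturated ring carbon is drawn without a configuration in compound 2 and R in compound 4. Because (the limit of > 350000 nM in this assay, at which 3 of the 3 values shown sit), no readable step is available, and no change beyond the scatter is expected in either direction. The step that the limit leaves unreadable from compound 2 to compound 4 is therefore expected to be negligible. Compound 4 is estimated at 500000 nM, with a range from 200000 nM to 2000000 nM, most likely reported as a limit again.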

Compound 4, half-maximal inhibitory concentration: > 350000 nM
Compound 4: a limit, no number; the forecaster's own chance of this, stated with the estimate: 85%; the middle value is on the limit's open side.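

No step can be read from compound 2 to compound 4, since both values in this assay are limits of the assay and not numbers: the limit of > 350000 nM in this assay, at which 4 of the 4 values shown sit.

The compounds shown leave open how potent any of them actually is in this assay, and whether configuration at the core changes that potency at all.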